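Replacing methylsulfanyl with chloro in compound 2

The source may report more compounds than this note shows. Statements on the series, on what has been measured and on what is new or still open speak of the compounds shown alone.

Among the compounds with values here, in a functional assay on U-87MG ATCC cells for inhibition, with U-87 MG (Homo sapiens) as the target, read by MTT assay, with a stated time of 48 h (a higher number here means a weaker inhibitor, a lower number a stronger inhibitor), compound 2 `CSc1ccc(-c2nc3ccccn3c2Sc2ccccc2)cc1` gives 26900 nM, the only exact number so far. Compound 1 `COc1ccc(-c2nc3ccccn3c2Sc2ccccc2)cc1` reads > 100000 nM, which is a limit and not a number. Compound 3 `Clc1ccc(-c2nc3ccccn3c2Sc2ccccc2)cc1` carries one change from compound 2: chloro in place of methylsulfanyl on an aromatic carbon, para to a large group. Within the data shown here, one measured step bears on this place: an at least 3.7-fold lower number from compound 1 to compound 2 (0.57 log units; beyond the scatter), with methylsulfanyl in place of methoxy. It suggests that changes here can matter, but it does not test chloro, so only a weak prediction is possible. The expected result is a 1.3-fold higher number from compound 2 to compound 3 (0.11 log units; within the scatter), slightly weaker and probably within the scatter. For compound 3 the estimated value is 35000 nM, with an expected range of 12000 nM to 100000 nM.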

Compound 3, half-maximal inhibitory concentration: 30200 nM
Compound 3: middle estimate off by 1.2-fold (0.06 log units), on the high side, within the range that was stated.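

Swapping methylsulfanyl for chloro gives a 1.1-fold higher number from compound 2 to compound 3 (0.05 log units; within the scatter) in this assay, so the two groups cannot be told apart at this position. Chloro in place of methoxy gives an at least 3.3-fold lower number from compound 1 to compound 3 (0.51 log units; beyond the scatter) as well, so methoxy alone stands apart among the three groups shown. Compound 1 reads > 100000 nM as a limit and not a number: the limit of > 100000 nM in this assay, at which 1 of the 3 values shown sits.

Still open, on these data alone, is whether an amine, a carboxylic acid or a longer chain at this place would read like chloro or like methoxy. As far as these compounds go, the true size of the gap to compound 1 also remains unknown.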